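Benzyloxy for furan-3-yl at the aryl carbon

This account rests on a few compounds, and the source may have more. Where it says the series, first, only, none or still open, it means among the compounds named here.

Compound 1 `Cc1ccccc1-n1nc(C)c2c1NC(=O)[C@H](C)S[C@@H]2c1ccc(-c2ccoc2)cc1` gives the lowest of the two numbers measured in an assay on isolated protein for agonist activity at Bile acid receptor (Homo sapiens), read by AlphaScreen, with a stated time of 30 min (a lower number here means that less compound is needed, a higher number that more compound is needed for the effect), at 3500 nM. Compound 2 `COc1ccc(C2SC(C)C(=O)Nc3c2c(C)nn3-c2ccccc2C)c(OC)c1` gives 10500 nM in this assay, a gap beyond the scatter. Among the compounds with values here, no single-change pair between measured compounds is available. Compound 3 `Cc1ccccc1-n1nc(C)c2c1NC(=O)[C@H](C)S[C@@H]2c1ccc(OCc2ccccc2)cc1` differs from compound 1 by benzyloxy in place of furan-3-yl on an aromatic carbon, placed on an aromatic carbon of a six-membered aromatic ring of carbon only. Both substituents carry one acceptor and no donor; the benzyloxy is larger. The step of a 1.4-fold lower number from compound 1 to compound 3 (0.15 log units; within the scatter) is expected to stay within or near the scatter, slightly toward a lower number. Compound 3 is estimated at 2500 nM, between 800 nM and 8000 nM in this assay.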

Compound 3, half-maximal effective concentration: "not active" (no number reported)
No number was reported for compound 3, and the estimate cannot be compared.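

Within the data shown here, compound 3 is reported as not active in this assay with no number, so no step from compound 1 to compound 3 can be read. The compounds shown leave open how benzyloxy compares with furan-3-yl at this place. No evidence bears on this result.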